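The source may hold more compounds than are shown below. What is called first, only, known or untested is meant among the compounds shown, and "the series" means these compounds.

Compound 1 `O=C(Nc1ccccc1)c1cc(Oc2ccc(/C=C/c3ccccn3)cc2)ccn1` and compound 2 `COc1ccc(CNC(=O)c2cc(Oc3ccc(/C=C/c4ccccn4)cc3)ccn2)cc1` share a core and differ only at the amide nitrogen. In a functional assay on HepG2 cells (Homo sapiens) for antiproliferative activity, read by CCK-8 assay, with a stated time of 48 h (on this read-out lower numbers stand for stronger inhibition and higher numbers for weaker inhibition), compound 1 gives 30200 nM, and compound 2 gives 26000 nM. Among the measured compounds shown here, the one measured step, a 1.2-fold lower number from compound 1 to compound 2 (0.07 log units; within the scatter), shows that exchanging these two nitrogen substituents leaves the read-out essentially unchanged. On the two numbers in hand compound 2 holds the lowest value, though its gap to compound 1 is within the scatter, so no order between them can be claimed.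

Compound 3 `O=C(c1cc(Oc2ccc(/C=C/c3ccccn3)cc2)ccn1)N1CCCC1` is the next member. Its change from compound 2 is pyrrolidin-1-yl in place of (4-methoxybenzyl)amino on a carbonyl carbon. For the measured compounds named here, no measured step covers this exchange; the only precedent, the step from compound 1 to compound 2, moved the number little. The expected step from compound 2 to compound 3 is therefore a 1.3-fold higher number from compound 2 to compound 3 (0.13 log units; within the scatter). Compound 3 is estimated at 35000 nM, expected between 12000 nM and 100000 nM.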

Compound 3, half-maximal inhibitory concentration: 27000 nM
Estimate against measurement, compound 3: 1.3-fold (0.11 log units) above; measured number inside the range.
By their numbers in this assay, from the lowest: compounds 2, 3 and 1 (each within the scatter of the next).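

Pyrrolidin-1-yl in place of (4-methoxybenzyl)amino gives a 1.0-fold higher number from compound 2 to compound 3 (0.02 log units; within the scatter) in this assay, and pyrrolidin-1-yl in place of anilino gives a 1.1-fold lower number from compound 1 to compound 3 (0.05 log units; within the scatter). At this carbonyl carbon, the read-out therefore stays within the scatter even when the substituent has no aromatic ring, 0 hydrogen-bond donors and fewer heavy atoms than (4-methoxybenzyl)amino. Nothing available here explains why these exchanges leave the number unchanged.

From the compounds shown here alone, it remains open whether any group on this carbonyl carbon can move the read-out beyond the scatter, for instance morpholin-4-yl, or an amide nitrogen carrying a carboxylic acid or a longer alkyl chain. The compounds also leave open whether a change elsewhere on the shared core would do so.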